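Chloro to bromo on the pyridine-like ring of compound 2

The source may hold more compounds than are shown below. What is called first, only, known or untested is meant among the compounds shown, and "the series" means these compounds.

Compound 1 `CNC1(COc2cccnc2)CC1`: 3 nM
Compound 2 `CNC1(COc2ccc(Cl)nc2)CC1`: 13 nM
Compound 3 `CN(C)C1(COc2ccc(Cl)nc2)CC1`: 304 nM

In an assay on brain for displacement of a labelled ligand from Neuronal acetylcholine receptor; alpha4/beta2 (Rattus norvegicus) (a lower number here means a stronger inhibitor, a higher number a weaker inhibitor), compound 2 stands second of the three. Compound 1 sits below it, the step being a 4.3-fold higher number from compound 1 to compound 2 (0.64 log units; beyond the scatter); compound 3 sits well above it, the step being a 23-fold higher number from compound 2 to compound 3 (1.37 log units; beyond the scatter).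

Compound 4 `CNC1(COc2ccc(Br)nc2)CC1` differs from compound 2 by bromo in place of chloro on an aromatic carbon. Within the data shown here, no measured step swaps one halogen for another, so none bears directly on this change. The step from compound 1 to compound 2 touches the same aromatic carbon and was modest, while the step from compound 2 to compound 3 concerns the amine nitrogen and says nothing about this position. With only the chloro-for-hydrogen step as a distant guide, the swap of chloro for bromo is expected to move this assay by little, and a step no larger than the scatter is anticipated, a 1.2-fold higher number from compound 2 to compound 4 (0.06 log units; within the scatter).

Compound 4 is therefore estimated at 15 nM in this assay, with a range from 6 nM to 40 nM.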

Compound 4, inhibition constant: 38.8 nM
Compound 4: middle estimate off by 2.6-fold (0.41 log units), on the low side; measured number inside the range.
By their numbers in this assay, from the lowest: compound 1; then compound 2; then compound 4; then compound 3.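

In this assay, the identity of the halogen on this aromatic carbon, next to the ring nitrogen, matters in its own right, as the swap gives a 3.0-fold higher number from compound 2 to compound 4 (0.47 log units; beyond the scatter). Measured against hydrogen at the same carbon, bromo gives a 13-fold higher number from compound 1 to compound 4 (1.11 log units; beyond the scatter), whereas chloro gives a 4.3-fold higher number from compound 1 to compound 2 (0.64 log units; beyond the scatter), so across these three compounds the number rises from hydrogen through chloro to bromo. Nothing measured here offers an explanation for this order.

From the compounds shown here alone, it remains open whether the rise continues with iodo, and where fluoro, methyl or nitrile on this carbon would fall in the order. Also open, going by these compounds, is whether bromo in place of chloro would produce a step of similar size with the second methyl on the amine nitrogen, as in compound 3.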